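This account rests on a few compounds, and the source may have more. Where it says the series, first, only, none or still open, it means among the compounds named here.

Compound 3 `CC1=NC(C)=C([N+](=O)[O-])C(c2cccnc2)/C1=C(\O)OCC(C)C` gives 1740 nM in a functional assay (cardiac atrium) for agonist activity, with Cavia porcellus as the target (on this read-out higher numbers stand for an effect only at larger amounts of compound and lower numbers for an effect already at smaller amounts), the lowest of the three measured numbers; compound 2 `CC1=NC(C)=C([N+](=O)[O-])C(c2ccncc2)/C1=C(\O)OC1CCCCC1` gives 4940 nM and compound 1 `CCO/C(O)=C1\C(C)=NC(C)=C([N+](=O)[O-])C1c1ccncc1` gives 6460 nM, both beyond the scatter above compound 3. Compound 4 `CC1=NC(C)=C([N+](=O)[O-])C(c2ccncc2)/C1=C(\O)OCC(C)C` is not yet measured and differs from compound 3 in one place: pyridin-4-yl in place of pyridin-3-yl on a saturated ring carbon. For the measured compounds named here, no measured step covers this change directly. Going by the values given here, the only measured step, a 1.3-fold lower number from compound 1 to compound 2 (0.12 log units; within the scatter), concerns cyclohexyl in place of ethyl on an oxygen and lies within the scatter, so the gap between compounds 1 and 2 on one side and compound 3 on the other is best read as going with pyridin-4-yl against pyridin-3-yl. A rise toward the numbers of compounds 1 and 2 is therefore expected in this assay. For compound 4 the expected step is a 2.6-fold higher number from compound 3 to compound 4 (0.41 log units; beyond the scatter). Compound 4 is estimated at 4500 nM, with a range from 2000 nM to 10000 nM.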

Compound 4, half-maximal effective concentration: 8510 nM
Compound 4: the middle estimate sits 1.9-fold (0.28 log units) below what was measured; the measured number falls inside the stated range.
By their numbers in this assay, from the lowest: compound 3; then compounds 2, 1 and 4 (each within the scatter of the next).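

In this assay, for the compounds shown here, the swap at the saturated ring carbon is the first step read at this position, and pyridin-4-yl in place of pyridin-3-yl gives a 4.9-fold higher number from compound 3 to compound 4 (0.69 log units; beyond the scatter). With pyridin-4-yl held, the oxygen substituent separates little, with a 1.7-fold higher number from compound 2 to compound 4 (0.24 log units; within the scatter) and a 1.3-fold higher number from compound 1 to compound 4 (0.12 log units; within the scatter), so no order among ethyl, cyclohexyl and isobutyl can be read. Nothing at hand gives a reason for the pyridine difference.

Going by these compounds, whether pyridin-3-yl keeps its lower number with ethyl or cyclohexyl on the oxygen remains open. So does where pyridin-2-yl or phenyl would fall at this ring carbon.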